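The compounds below may be only part of what the source reports. "The series", "measured", "known", "first", "only" and "open" are said of these compounds alone.

Measured compounds:
Compound 1, `COc1cc2c(Oc3ccc(NC(=O)c4cc(-c5cccc(Cl)c5)nc5ccccc45)cc3F)ccnc2cc1OCCCN1CCCCC1`, 11 nM
Compound 2, `COc1cc2c(Oc3ccc(NC(=O)c4cc(-c5ccc(Cl)c(Cl)c5)nc5ccccc45)cc3F)ccnc2cc1OCCCN1CCCCC1`, 820 nM
Compound 3, `COc1cc2c(Oc3ccc(NC(=O)c4cc(-c5ccccc5)nc5ccc(F)cc45)cc3F)ccnc2cc1OCCCN1CCCC1`, 90 nM

All three were tested in a functional assay on NCI-H460 cells (Homo sapiens) for cytotoxicity, read by MTT assay, with a stated time of 72 h; on this read-out higher numbers stand for weaker inhibition and lower numbers for stronger inhibition. Compound 1 gives 11 nM there, the lowest of the three numbers, while compound 2 gives 820 nM. The two differ in one place, (chloro in place of hydrogen on an aromatic carbon), sitting ortho to a chloro group and para to a large group, and this change produced a 75-fold higher number from compound 1 to compound 2 (1.87 log units; beyond the scatter). Compound 3 gives 90 nM in this assay; the difference between its core and the core of compound 1 is not broken down here, and the two values alone show compound 3 standing between compound 1 and compound 2.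

Compound 4, `COc1cc2c(Oc3ccc(NC(=O)c4cc(-c5cccc(Cl)c5)nc5ccc(F)cc45)cc3F)ccnc2cc1OCCCN1CCCC1`, has not yet been measured. It differs from compound 3 in one place, (chloro in place of hydrogen on an aromatic carbon), here meta to a large group rather than ortho to a chloro group and para to a large group, so it is the same kind of change as that from compound 1 to compound 2, not the same change. The earlier step of a 75-fold higher number from compound 1 to compound 2 (1.87 log units; beyond the scatter) was a large loss, yet compound 1, which carries the 3-chlorophenyl, gives the lowest number, 11 nM. Compound 4 is therefore expected to give 40 nM in this assay, likely between 10 nM and 200 nM. This estimate means an expected step of a 2.3-fold lower number from compound 3 to compound 4 (0.35 log units; beyond the scatter).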

Compound 4, half-maximal inhibitory concentration: 72 nM
Estimate against measurement, compound 4: 1.8-fold (0.26 log units) below; the measured number falls inside the stated range.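

Set side by side in this assay, the two steps show that adding a chloro to an aromatic carbon does not have one fixed outcome across the cores of this series: the same change on two cores in this assay, a 75-fold higher number (1.87 log units; beyond the scatter) from compound 1 to compound 2 and a 1.3-fold lower number (0.10 log units; within the scatter) from compound 3 to compound 4, 93-fold (1.97 log units) apart, beyond the scatter of two such steps The new step, a 1.3-fold lower number from compound 3 to compound 4 (0.10 log units; within the scatter), shows that going from phenyl to 3-chlorophenyl on the core of compound 3 leaves the number unchanged within the scatter, unlike the large loss seen on the core of compound 1. This does not show that the core alone sets the outcome, since the chloro also enters at a different place on the ring in the two steps, and a single pair on each core cannot separate these two differences.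

Going by these compounds alone, it remains open whether a second chloro on the 3-chlorophenyl of compound 4 would bring a loss like the one seen with compound 2. Going by these compounds, it also remains open how an amine or a nitrile at the same place on the phenyl of compound 3 would read in this assay.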